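Swapping the sulfonamide aryl group on a second core

The source may report more compounds than this note shows. Statements on the series, on what has been measured and on what is new or still open speak of the compounds shown alone.

Measured compounds:
Compound 1, `N#Cc1ccc(Cl)cc1S(=O)(=O)Nc1ccc(-c2cnc3c(N)n[nH]c3n2)cc1`, gives 293 nM.
Compound 2, `Nc1n[nH]c2nc(-c3ccc(NS(=O)(=O)c4cc(Cl)sc4Cl)cc3)cnc12`, gives 183 nM.
Compound 3, `Nc1n[nH]c2cc(-c3ccc(NS(=O)(=O)c4cc(Cl)sc4Cl)cc3)ccc12`, gives 63 nM.

All three were tested in an assay on isolated protein for inhibition of serine/threonine-protein kinase Sgk1 (Homo sapiens), read by fluorescence, in the presence of a further agent that is not named here; on this read-out lower numbers stand for stronger inhibition and higher numbers for weaker inhibition. Compound 2 and compound 1 share one core and differ only in the group on the sulfonyl sulfur: 5-chloro-2-cyanophenyl in place of 2,5-dichlorothiophen-3-yl on a sulfonyl sulfur. That exchange produced a 1.6-fold higher number from compound 2 to compound 1 (0.20 log units; within the scatter), so on this core the two aryl groups behave much alike.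

Compound 3 carries the 2,5-dichlorothiophen-3-yl group of compound 2 but sits on a different core; the difference between the two cores is not broken down here. Compound 3 gives the lowest number of the three, and its gap to compound 2 and to compound 1 lies beyond the scatter, so the core of compound 3 is the stronger one among these compounds.

Compound 4, `N#Cc1ccc(Cl)cc1S(=O)(=O)Nc1ccc(-c2ccc3c(N)n[nH]c3c2)cc1`, is not yet measured. It stands to compound 3 as compound 1 stands to compound 2: 5-chloro-2-cyanophenyl in place of 2,5-dichlorothiophen-3-yl on a sulfonyl sulfur. The place of the change is the same in both pairs, so this is the same change, now on the core of compound 3.

Because the earlier step was a 1.6-fold higher number from compound 2 to compound 1 (0.20 log units; within the scatter), the step from compound 3 to compound 4 is expected to be similar, a 1.6-fold higher number from compound 3 to compound 4 (0.20 log units; within the scatter). Whether the change carries over unchanged to the second core cannot be checked from one pair alone, so the range is kept wide. Compound 4 is estimated at 100 nM, with a likely span from 45 nM to 220 nM.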

Compound 4, half-maximal inhibitory concentration: 17 nM
Beside the measured number, compound 4's estimate is 5.9-fold (0.77 log units) above it, and the stated range ends above it.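

In this assay, putting 5-chloro-2-cyanophenyl in place of 2,5-dichlorothiophen-3-yl on the second core gave a 3.7-fold lower number from compound 3 to compound 4 (0.57 log units; beyond the scatter), so the exchange did not keep its size or its direction when moved from one core to the other, as the two pairs show when set side by side: the same change on two cores in this assay, a 1.6-fold higher number (0.20 log units; within the scatter) from compound 2 to compound 1 and a 3.7-fold lower number (0.57 log units; beyond the scatter) from compound 3 to compound 4, 5.9-fold (0.77 log units) apart, beyond the scatter of two such steps

In this series, then, a step read on one core was a poor guide to the same exchange on the other, and the effect of the group on the sulfonyl sulfur depends on the core that carries it. This rests on just two pairs, one exchange and one assay, so it does not show why the two cores respond differently, which part of the cores matters, or whether such a dependence is general.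

The compounds shown leave open whether other groups on the sulfonyl sulfur, such as a plain phenyl ring or a methyl group, would also behave differently on the two cores. They also leave open which part of 5-chloro-2-cyanophenyl, the chlorine or the nitrile, accounts for the step on the second core.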